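The source may report more compounds than this note shows. Statements on the series, on what has been measured and on what is new or still open speak of the compounds shown alone.

Measured so far in an assay for inhibition of histone deacetylase 8 (Homo sapiens), read by fluorescence, with stated times of 15 min and 60 min; a lower number here means a stronger inhibitor, a higher number a weaker inhibitor:
Compound 1 `Nc1cc(O)ccc1NC(=O)c1ccc(CNc2nccc(-c3cccnc3)n2)cc1`: in this assay compound 1 gives > 20000 nM, which is a limit of the assay.
Compound 2 `Nc1cc(C(=O)OCc2ccccc2)ccc1NC(=O)c1ccc(CNc2nccc(-c3cccnc3)n2)cc1`: in this assay compound 2 gives > 20000 nM, again a limit of the assay.

Compound 2 thus stands at the limit of this assay, as does compound 1. The step from compound 1 to compound 2 is a step that the two limits leave unreadable from compound 1 to compound 2, a step that the limit of > 20000 nM in this assay, at which 2 of the 2 values shown sit, leaves unreadable in size and direction. Compound 3 `CC(C)(C)[Si](C)(C)OCc1ccc(NC(=O)c2ccc(CNc3nccc(-c4cccnc4)n3)cc2)c(N)c1` has not yet been measured in this assay. It differs from compound 2 by a group of 9 heavy atoms (7 carbon, 1 oxygen, 1 silicon; no ring) in place of a group of 10 heavy atoms (8 carbon, 2 oxygen; one six-membered aromatic ring of carbon only), on an aromatic carbon. Among the compounds with values here, the only measured step, from compound 1 to compound 2, has no readable size, so it gives no guide to how large a step in this assay to expect, nor in which direction. With nothing pointing away from the limit, compound 3 is expected to sit near it as well, with an estimated step of a number no higher from compound 2 to compound 3 (the limit leaves the size open). The estimate for compound 3 in this assay is 20000 nM, ranging from 4000 nM to 80000 nM.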

Compound 3, half-maximal inhibitory concentration: > 20000 nM
Compound 3 ended at the assay's limit; the forecaster's own chance of this, stated with the estimate: 80%; the middle value lies on the limit itself.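

No new step can be read, since the steps from compound 1 and compound 2 to compound 3 all end at a limit of this assay: the limit of > 20000 nM in this assay, at which 3 of the 3 values shown sit. The compounds shown leave open what size any of these changes on the shared core has, and in which direction.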